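This account rests on a few compounds, and the source may have more. Where it says the series, first, only, none or still open, it means among the compounds named here.

Measured compounds:
Compound 1, `OCCOCn1c(Cl)nc2cc(Cl)c(Cl)cc21`, gives in a functional assay on KB cells (Homo sapiens) for inhibition (on this read-out higher numbers stand for weaker inhibition and lower numbers for stronger inhibition), a value that is only an assay limit, > 320000 nM.
Compound 2, `CN(C)c1nc2cc(Cl)c(Cl)cc2n1COCCO`, gives in this assay a value that is only an assay limit, > 100000 nM.
Compound 3, `OCCOCn1cnc2cc(Cl)c(Cl)cc21`, gives in this assay a value that is only an assay limit, > 100000 nM.

Compound 3 thus stands at a limit and not at a number; all three values shown are limits, two sitting at the limit of > 100000 nM in this assay, at which 2 of the 3 values shown sit, and one at the limit of > 320000 nM in this assay, at which 1 of the 3 values shown sits. Compound 4, `OCCOCn1c(Br)nc2cc(Cl)c(Cl)cc21`, differs from compound 3 by bromo in place of hydrogen on an aromatic carbon. The step that bears on this is a step that the two limits leave unreadable from compound 1 to compound 3, which also exchanges a halogen for hydrogen; the steps a step that the two limits leave unreadable from compound 1 to compound 2 and a step that the two limits leave unreadable from compound 2 to compound 3 are likewise unreadable. No readable size or direction can be drawn from them. In this assay compound 4 is therefore expected to give 150000 nM, between 40000 nM and 500000 nM. The expected step that the limit leaves unreadable from compound 3 to compound 4 is none beyond the scatter.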

Compound 4, half-maximal inhibitory concentration: > 100000 nM
Compound 4: only a limit was reported; the forecaster's own chance of this, stated with the estimate: 85%; the middle value is on the limit's open side.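

In this assay compound 4 gives > 100000 nM, which is only a limit. Within the data shown here, no step to compound 4 from compound 1, compound 2 or compound 3 can be read. The compounds shown leave open how strongly, if at all, any of the four inhibits.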